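This account rests on a few compounds, and the source may have more. Where it says the series, first, only, none or still open, it means among the compounds named here.

Measured compounds:
compound 1 `O=C1Nc2cccc(Cl)c2/C1=N/NC(=S)N1CCN(c2ccccc2)CC1`: 42100 nM
compound 2 `COc1ccc(N2CCN(C(=S)N/N=C3\C(=O)Nc4ccc(Cl)cc43)CC2)cc1`: 7740 nM

In a functional assay on HCT-116 cells (Homo sapiens) for inhibition, read by MTT assay, with a stated time of 72 h (on this read-out lower numbers stand for stronger inhibition and higher numbers for weaker inhibition), compound 2 gives 7740 nM, the lower of the two numbers, while compound 1 gives 42100 nM, a higher number beyond the usual scatter. Compound 3 `O=C1Nc2ccc(Cl)cc2/C1=N/NC(=S)N1CCN(c2ccc(F)cc2F)CC1` has not been measured. It differs from compound 2 in one place: 2,4-difluorophenyl in place of 4-methoxyphenyl on an amine nitrogen in a ring. No comparable change between measured compounds is available, so the size of the step in this assay is uncertain, and only a small move, probably within the scatter, is expected. Compound 3 is estimated at 10000 nM, with a range from 3000 nM to 35000 nM. The step of a 1.3-fold higher number from compound 2 to compound 3 (0.11 log units; within the scatter) is expected to be small.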

Compound 3, half-maximal inhibitory concentration: 5890 nM
The estimate for compound 3 lay 1.7-fold (0.23 log units) above the measured number; the range from low to high includes it.
By their numbers in this assay, from the lowest: compounds 3 and 2 (each within the scatter of the next); then compound 1.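

In this assay, 2,4-difluorophenyl in place of 4-methoxyphenyl on the amine nitrogen in the ring gives a 1.3-fold lower number from compound 2 to compound 3 (0.12 log units; within the scatter). This first single-place step shows that this position tolerates the exchange of these two substituted phenyl groups, even though the hydrogen-bond acceptor of the 4-methoxyphenyl group is lost, with no change beyond the scatter. Nothing measured here bears on the reason for this result. Going by these compounds, whether an amine or a carboxylic acid on this aromatic ring would shift the number remains open. So does the effect of replacing the aromatic ring with a longer chain.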